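This account rests on a few compounds, and the source may have more. Where it says the series, first, only, none or still open, it means among the compounds named here.

Three compounds that share one core and differ only in the aryl group attached to the carbon with a double bond to nitrogen have been measured in a functional assay on MKN-45 cells (Homo sapiens) for cytotoxicity, read by MTT assay, with a stated time of 72 h; a lower number here means a stronger inhibitor, a higher number a weaker inhibitor. Compound 1 `CN(C)CCn1cnnc1-c1cc(Oc2ccc(NC(=O)N/N=C/c3ccc(F)cc3Cl)cc2F)ccn1` gives 870 nM. Compound 2 `CN(C)CCn1cnnc1-c1cc(Oc2ccc(NC(=O)N/N=C/c3ccc(O)c(F)c3)cc2F)ccn1` gives 1970 nM, the second highest of the three numbers; its nearest neighbour is compound 3 `CN(C)CCn1cnnc1-c1cc(Oc2ccc(NC(=O)N/N=C/c3cc(C(C)(C)C)cc(C(C)(C)C)c3O)cc2F)ccn1`, which gives 3300 nM, a gap that lies within the scatter, while its step to compound 1 lies beyond it. For the measured compounds named here, the one step between these compounds that changes a single place is the exchange of aryl groups, a 2.3-fold higher number from compound 1 to compound 2 (0.35 log units; beyond the scatter).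

Compound 4 `COc1ccc(/C=N/NC(=O)Nc2ccc(Oc3ccnc(-c4nncn4CCN(C)C)c3)c(F)c2)c(OC)c1` has not been measured. It differs from compound 2 in one place: 2,4-dimethoxyphenyl in place of 3-fluoro-4-hydroxyphenyl on a carbon with a double bond to nitrogen. Going by the values given here, the only measured step at this position is the modest one from compound 1 to compound 2, and the three measured aryl variants span a narrow band of numbers. A further swap of the aryl group is therefore expected to move the number little, in either direction, most likely staying within the scatter of compound 2.

For compound 4 in this assay the estimate is 1500 nM, with a range from 600 nM to 4000 nM, which is expected to be a step of a 1.3-fold lower number from compound 2 to compound 4 (0.12 log units; within the scatter).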

Compound 4, half-maximal inhibitory concentration: 1680 nM
Compound 4: the middle estimate sits 1.1-fold (0.05 log units) below what was measured; measured number inside the range.
By their numbers in this assay, from the lowest: compounds 1, 4, 2 and 3 (each within the scatter of the next, the first and the last beyond it).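

In this assay, the step of a 1.2-fold lower number from compound 2 to compound 4 (0.07 log units; within the scatter) shows that this position tolerates a larger change than the first pair suggested: 2,4-dimethoxyphenyl has no hydrogen-bond donor and one more hydrogen-bond acceptor than 3-fluoro-4-hydroxyphenyl, yet the number stays within the scatter. The second new step, a 1.9-fold higher number from compound 1 to compound 4 (0.29 log units; within the scatter), also stays within the scatter, even though the earlier step of a 2.3-fold higher number from compound 1 to compound 2 (0.35 log units; beyond the scatter) lies just beyond it, so compound 4 falls within reach of both compound 1 and compound 2 and these aryl groups read as one shallow band rather than as separate levels. Nothing available explains why these different aryl groups give such similar numbers.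

All the compounds shown carry a substituted phenyl group at this position, so it remains open whether a phenyl ring bearing an amine or a carboxylic acid, or a longer alkyl chain in place of the ring, would stay in this band. From the compounds shown here alone, it is also open whether any group here could move the number well beyond the scatter in either direction.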